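The source may hold more compounds than are shown below. What is called first, only, known or untested is meant among the compounds shown, and "the series" means these compounds.

Measured so far:
- compound 1 `COc1c(OCc2cnoc2C)cc(O)c2c(=O)cc(-c3ccccc3)oc12`: > 100000 nM
- compound 2 `CN1CCN(CCCCOc2c(O)cc(O)c3c(=O)cc(-c4ccccc4)oc23)CC1`: > 100000 nM
- compound 3 `COc1c(O)cc(O)c2c(=O)cc(-c3ccc(C)cc3)oc12`: "not determined" (no result reported)

In a functional assay on A549 cells (Homo sapiens) for cytotoxicity, read by MTT assay, with a stated time of 48 h (on this read-out higher numbers stand for weaker inhibition and lower numbers for stronger inhibition), compound 1 gives > 100000 nM, which is a limit and not a number. Compound 2 gives > 100000 nM, also a limit. Compound 3 has no reported result, "not determined" (no result reported). Among the measured compounds shown here, compound 1 therefore stands at the limit of > 100000 nM in this assay, at which 2 of the 3 values shown sit, and no measured step is available to calibrate a change.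

The next compound is compound 4 `COc1c(OCCCNCc2ccccc2)cc(O)c2c(=O)cc(-c3ccccc3)oc12`. The difference is 2-(benzylamino)ethyl in place of 5-methyl-1,2-oxazol-4-yl on a saturated chain carbon bound to an oxygen on an aromatic ring.

With only a limit as the starting point, the size of any change in this assay is poorly constrained, and a further result at the limit remains possible. A modest move toward stronger inhibition is expected, shown as the estimated at least 2.8-fold lower number from compound 1 to compound 4 (0.45 log units; beyond the scatter). For compound 4 the estimated value is 35000 nM, with an expected range of 9000 nM to 100000 nM.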

Compound 4, half-maximal inhibitory concentration: 1570 nM
Compound 4: the middle estimate sits 22-fold (1.35 log units) above what was measured, outside the stated range (below it).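

In this assay, among the compounds shown here, the saturated chain carbon bound to an oxygen on an aromatic ring proves to be a place where a change of group registers: 2-(benzylamino)ethyl in place of 5-methyl-1,2-oxazol-4-yl gives an at least 63-fold lower number from compound 1 to compound 4 (1.80 log units; beyond the scatter), the first readable step. Compound 1 carries a limit, > 100000 nM, and not a number. The step therefore fixes only a minimum for the change and not its full size, because compound 1 sits at the limit: the limit of > 100000 nM in this assay, at which 2 of the 4 values shown sit.

Which part of the entering group carries the change stays open, as the compounds shown do not separate the benzyl ring from the amine nitrogen. A primary amine or a shorter chain at this place would test that.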